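Serum half-life of thymidine azide prodrugs: a carbonate analogue

The compounds below may be only part of what the source reports. "The series", "measured", "known", "first", "only" and "open" are said of these compounds alone.

Compound 1 `Cc1cn(C2CC(N=[N+]=[N-])C(COC(=O)CCCC(=O)OC(C)(C)C)O2)c(=O)[nH]c1=O`: 0.55 h
Compound 2 `Cc1cn(C2CC(N=[N+]=[N-])C(COC(=O)NCCCC(=O)O)O2)c(=O)[nH]c1=O`: > 48 h
Compound 3 `Cc1cn(C2CC(N=[N+]=[N-])C(COC(=O)CCCN)O2)c(=O)[nH]c1=O`: 0.433 h

Three compounds sharing one core have been run in an ADME assay on the whole organism (serum) with Homo sapiens as the target; on this read-out higher numbers stand for a longer-lived compound and lower numbers for a shorter-lived compound. Compound 1 gives 0.55 h in this assay. For compound 2 this assay reports only a limit, > 48 h. Compound 3 gives 0.433 h in this assay, the lowest of the two numbers, with compound 1 as its nearest neighbour; the two differ by a 1.3-fold lower number from compound 1 to compound 3 (0.10 log units; within the scatter), so neither can be called shorter-lived than the other. The step from compound 2 to compound 3 was an at least 110-fold lower number from compound 2 to compound 3 (2.04 log units; beyond the scatter), a change set by the limit (the limit of > 48 h in this assay, at which 1 of the 3 values shown sits).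

Compound 4 `CCCCOC(=O)OCC1OC(n2cc(C)c(=O)[nH]c2=O)CC1N=[N+]=[N-]` is not yet measured. It differs from compound 3 by butoxy in place of 3-aminopropyl on a carbonyl carbon; the place is a carbonyl carbon whose other neighbours are oxygen next to a carbonyl group. Going by the values given here, the measured steps on a saturated chain carbon, such as the one from compound 1 to compound 3, were small, while the step that replaced the group on the carbonyl carbon itself was large. Compound 4 is estimated to give 1 h in this assay, between 0.3 h and 5 h, which would be a step of a 2.3-fold higher number from compound 3 to compound 4 (0.36 log units; beyond the scatter) from compound 3.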

Compound 4, half-life: 0.15 h
Compound 4: the middle estimate sits 6.7-fold (0.82 log units) above what was measured; the measured number lies below the stated range.
By their numbers in this assay, from the lowest: compound 4; then compounds 3 and 1 (each within the scatter of the next). At a limit, above all of these: compound 2.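

Compounds 1 and 3 could not be told apart, so the short-lived end of the series had looked like a single level. With butoxy on the carbonyl carbon, whose other neighbours are oxygen next to a carbonyl group, the readings in this assay show a 2.9-fold lower number from compound 3 to compound 4 (0.46 log units; beyond the scatter) and a 3.7-fold lower number from compound 1 to compound 4 (0.56 log units; beyond the scatter), which sets compound 4 apart at the low end. The widest gap shown is an at least 320-fold lower number from compound 2 to compound 4 (2.50 log units; beyond the scatter), and it is set by a limit, the value of compound 2: the limit of > 48 h in this assay, at which 1 of the 4 values shown sits. The group on this carbonyl carbon therefore moves the number in both directions, with butoxy in compound 4 at the short-lived end, (3-carboxypropyl)amino in compound 2 at the long-lived end, and the groups of compounds 1 and 3 in between with no order among them.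

The compounds shown leave open whether the amino link or the carboxylic acid of compound 2 goes with its long half-life, and a butylamino group on the same carbonyl carbon, or a carboxylic acid at the end of a butoxy chain, would separate the two. They also cannot say how far the number depends on chain length, since a longer chain on the oxygen of compound 4 does not appear among them.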